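The source may hold more compounds than are shown below. What is called first, only, known or untested is meant among the compounds shown, and "the series" means these compounds.

Measured compounds in an assay on isolated protein for inhibition of Fatty-acid amide hydrolase 1 (Homo sapiens), with a stated time of 15 min; on this read-out higher numbers stand for weaker inhibition and lower numbers for stronger inhibition:
- compound 1, `CCCCCCCCCC[S+]([O-])CC(=O)C(F)(F)F`: compound 1 gives 1350 nM
- compound 2, `CCCCCCCCCCCC[S+]([O-])CC(=O)C(F)(F)F`: compound 2 gives 600 nM
- compound 3, `CCCCCCCCCCS(=O)(=O)CC(=O)C(F)(F)F`: compound 3 gives 3000 nM

Compound 3 stands at the highest of the three numbers in this assay. The nearest number is that of compound 1, which is lower and beyond the scatter; the furthest is that of compound 2, lower again and well beyond the scatter. Between compound 1 and compound 2 there is one counted step, a 2.3-fold lower number from compound 1 to compound 2 (0.35 log units; beyond the scatter), a modest lowering of the number.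

Compound 4, `CCCCCCCCCCCCS(=O)(=O)CC(=O)C(F)(F)F`, is not yet measured in this assay. It differs from compound 3 by ethyl in place of hydrogen on a saturated chain carbon, ten or more bonds along the chain from a sulfonyl sulfur. Going by the values given here, the only measured step that bears on this change is the one from compound 1 to compound 2, the same chain extension carried out on a different sulfur oxidation state, which gave a 2.3-fold lower number from compound 1 to compound 2 (0.35 log units; beyond the scatter). Among the compounds with values here, no other pair in the set speaks to the chain extension. On that single precedent the expectation for compound 4 is a lowering of the number of similar modest size, a 2.3-fold lower number from compound 3 to compound 4 (0.36 log units; beyond the scatter), with the direction taken as more reliable than the exact size. Compound 4 is therefore estimated at 1300 nM, with a range from 600 nM to 3000 nM in this assay.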

Compound 4, half-maximal inhibitory concentration: 280 nM
Estimate against measurement, compound 4: 4.6-fold (0.67 log units) above, outside the stated range (below it).
By their numbers in this assay, from the lowest: compound 4; then compound 2; then compound 1; then compound 3.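

In this assay, ethyl in place of hydrogen at this place on the chain gives an 11-fold lower number from compound 3 to compound 4 (1.03 log units; beyond the scatter), so the lowering seen earlier also holds on the sulfonyl core and is large there. The same chain extension therefore does not carry a single size from one core to the other: the same change on two cores in this assay, a 2.3-fold lower number (0.35 log units; beyond the scatter) from compound 1 to compound 2 and an 11-fold lower number (1.03 log units; beyond the scatter) from compound 3 to compound 4, 4.8-fold (0.68 log units) apart, beyond the scatter of two such steps With these two steps, the order of the two sulfur oxidation states also turns over with chain length: among the shorter chains, compound 1 gives 1350 nM and compound 3 gives the higher 3000 nM, while among the longer chains, compound 2 gives 600 nM and compound 4 gives the lower 280 nM.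

Each core is shown at only two chain lengths, so it remains open whether a longer chain would lower the number further on either core or whether the gap between the two steps would keep widening. The neutral sulfide at the same chain lengths, and a chain ending in a phenyl ring or a carboxylic acid, would test whether this dependence on the sulfur oxidation state extends beyond the saturated chains shown here.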